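The source may hold more compounds than are shown below. What is called first, only, known or untested is meant among the compounds shown, and "the series" means these compounds.

Series notes. Compound 1 `COc1cc(OC)c(C(=O)/C=C/c2ccccc2SC)c(OC)c1` and compound 2 `COc1cccc(/C=C/C(=O)c2c(OC)cc(OC)cc2OC)c1` share the core of compound 1 apart from the change (3-methoxyphenyl in place of 2-(methylsulfanyl)phenyl on a double-bonded chain carbon bound to a double-bonded chain carbon); in a functional assay on MCF7 cells (Homo sapiens) for cytotoxicity, with a stated time of 48 h (a lower number here means a stronger inhibitor, a higher number a weaker inhibitor), compound 1 gives 9300 nM and compound 2 gives 9400 nM, the step being a 1.0-fold higher number from compound 1 to compound 2 (0.00 log units; within the scatter). Compound 3 `COc1cc(O)c(C(=O)/C=C/c2ccccc2SC)c(OC)c1` is compound 1 with the change (hydrogen in place of methyl on an oxygen on an aromatic ring); in this assay compound 3 gives 15900 nM, the step of a 1.7-fold higher number from compound 1 to compound 3 (0.23 log units; within the scatter). Compound 4 `COc1cccc(/C=C/C(=O)c2c(O)cc(OC)cc2OC)c1` is compound 2 with the change (hydrogen in place of methyl on an oxygen on an aromatic ring), the same change made twice in all among these compounds. The step from compound 2 to compound 4 in this assay is expected to be a 1.6-fold higher number from compound 2 to compound 4 (0.20 log units; within the scatter), a size resting on compound 3 and its step of a 1.7-fold higher number from compound 1 to compound 3 (0.23 log units; within the scatter) and on the near-equal values of compound 1 and compound 2. For compound 4 the estimate in this assay is 15000 nM, with a range from 7000 nM to 35000 nM.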

Compound 4, half-maximal inhibitory concentration: 10300 nM
The estimate for compound 4 lay 1.5-fold (0.16 log units) above the measured number; the range from low to high includes it.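

Series notes, continued. In this assay, the change from methoxy to hydroxy on the core of compound 2 gives a 1.1-fold higher number from compound 2 to compound 4 (0.04 log units; within the scatter). Set beside the same change on the core of compound 1, the new step does not differ from the earlier one: the same change on two cores in this assay, a 1.7-fold higher number (0.23 log units; within the scatter) from compound 1 to compound 3 and a 1.1-fold higher number (0.04 log units; within the scatter) from compound 2 to compound 4, 1.6-fold (0.19 log units) apart, within the scatter of two such steps. Across these two cores the change therefore carries over with no detectable difference, but both steps lie within the scatter, so this shows neither a real effect of the change on either core nor a rule for the wider series.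

Open, from the compounds shown here alone, is whether a longer chain such as ethoxy on that oxygen, or an amine in place of the hydroxy, would give a step beyond the scatter in this assay. Also open, going by these compounds, is whether the change carries over in the same way on a core bearing a carboxylic acid.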